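The compounds below may be only part of what the source reports. "The series", "measured", "known", "first", "only" and "open" are said of these compounds alone.

Measured compounds:
compound 1 `Cc1ccc(C2C(C#N)=C(N)N(c3ccc(S(N)(=O)=O)cc3)C3=C2CCCC3)cc1`, 30%
compound 2 `N#CC1=C(N)N(c2ccc(S(N)(=O)=O)cc2)C2=C(CCCC2)C1c1ccccc1O`, 40%
compound 3 `N#CC1=C(N)N(c2ccc(S(N)(=O)=O)cc2)C2=C(CCCC2)C1/C=C/c1ccccc1`, 70%

In a functional assay on Ehrlich cells (Mus musculus) for cytotoxicity, read by trypan blue exclusion, with a stated time of 2 h, tested at 25 ug/mL (on this read-out higher numbers stand for a stronger effect at the one concentration tested and lower numbers for a weaker effect), compound 1 gives 30% and stands lowest of the three numbers, with compound 2 nearest and compound 3 furthest. The step from compound 1 to compound 4 `N#CC1=C(N)N(c2ccc(S(N)(=O)=O)cc2)C2=C(CCCC2)C1c1cccs1` puts (thiophen-2-yl in place of 4-methylphenyl on a saturated ring carbon). Among the compounds with values here, two measured steps bear on it: a number 10 percentage points higher from compound 1 to compound 2 (within the scatter), and a number 40 percentage points higher from compound 1 to compound 3 (beyond the scatter). The swap of one aromatic ring for another, as in compound 2, stayed within the scatter, while the change to an open 2-phenylethenyl chain in compound 3 went well beyond it. A thiophen-2-yl ring resembles the first case, so no step beyond the scatter is expected: a number 5 percentage points higher from compound 1 to compound 4 (within the scatter). Compound 4 is therefore estimated at 35%, between 20% and 55%.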

Compound 4, a percentage reported as activity, at one concentration (the size of the read-out at that concentration, not a potency): 5%
The estimate for compound 4 lay 30 percentage points above the measured number; the measured number lies below the stated range.
By their numbers in this assay, from the lowest: compound 4; then compounds 1 and 2 (each within the scatter of the next); then compound 3.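

In this assay, thiophen-2-yl on this saturated ring carbon gives a number 25 percentage points lower from compound 1 to compound 4 (beyond the scatter), so exchanging one aromatic ring for another is not always a neutral change here, as the step to compound 2 had suggested. The group also falls short of the other two, with a number 35 percentage points lower from compound 2 to compound 4 (beyond the scatter) and a number 65 percentage points lower from compound 3 to compound 4 (beyond the scatter), which leaves compound 4 lowest of the four. No measurement shown explains this loss.

The compounds shown leave open whether the loss follows the ring sulfur or the five-membered ring. A furan-2-yl or thiophen-3-yl group at this carbon would help separate the two.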